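The compounds below may be only part of what the source reports. "The series", "measured", "known", "first", "only" and "open" are said of these compounds alone.

Three analogues of a shared core have numbers in an assay on HEK293 cells for inhibition of Voltage-dependent N-type calcium channel subunit alpha-1B (Homo sapiens), read by fluorescence and calcium flux, with a stated time of 5 min; on this read-out higher numbers stand for weaker inhibition and lower numbers for stronger inhibition. Compound 1 `COc1ccccc1-n1nc(C2CC(C)(C)OC(C)(C)C2)cc1-c1ccc(C#N)cc1` gives 1 nM, compound 2 `CCOc1ccc(-c2cc(C3CC(C)(C)OC(C)(C)C3)nn2-c2ccccc2OC)cc1` gives 2 nM, and compound 3 `COc1ccccc1-n1nc(C2CC(C)(C)OC(C)(C)C2)cc1-c1ccc(C)nc1` gives 6 nM; compound 3 thus has the highest of the three numbers. The measured steps of a 6.0-fold higher number from compound 1 to compound 3 (0.78 log units; beyond the scatter) and a 3.0-fold higher number from compound 2 to compound 3 (0.48 log units; beyond the scatter) show that exchanging the aromatic group on this carbon moves this assay only modestly, while a 2.0-fold higher number from compound 1 to compound 2 (0.30 log units; within the scatter) stays within the scatter. Compound 4 `COc1ccccc1-n1nc(C2CC(C)(C)OC(C)(C)C2)cc1-c1csc(Cl)c1` carries 5-chlorothiophen-3-yl in place of 6-methylpyridin-3-yl on an aromatic carbon. Among the compounds with values here, no measured pair exchanges a six-membered for a five-membered aromatic group here, so the three steps give only a range of modest shifts among aryl groups. The expected step of a 1.5-fold lower number from compound 3 to compound 4 (0.18 log units; within the scatter) is therefore small and toward a lower number. Compound 4 is estimated at 4 nM, between 1.5 nM and 12 nM.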

Compound 4, half-maximal inhibitory concentration: 6 nM
Estimate against measurement, compound 4: 1.5-fold (0.18 log units) below; the range from low to high includes it.
By their numbers in this assay, from the lowest: compounds 1 and 2 (each within the scatter of the next); then compounds 3 and 4 (each within the scatter of the next).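

Swapping the six-membered ring for a five-membered one at this aromatic carbon, 5-chlorothiophen-3-yl for 6-methylpyridin-3-yl, gives no change at the digits printed from compound 3 to compound 4 (within the scatter) in this assay, so this exchange of ring size and hetero atom does not separate the two groups. Against the other aryl groups, the new group shows a 3.0-fold higher number from compound 2 to compound 4 (0.48 log units; beyond the scatter) and a 6.0-fold higher number from compound 1 to compound 4 (0.78 log units; beyond the scatter), the same modest steps as 6-methylpyridin-3-yl. No evidence bearing on these results is available. As far as these compounds go, it remains open whether an aryl group carrying a carboxylic acid or an aminomethyl group at this carbon stays in this range. Exchange of the 2-methoxyphenyl or 2,2,6,6-tetramethyloxan-4-yl group also remains open.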